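This account rests on a few compounds, and the source may have more. Where it says the series, first, only, none or still open, it means among the compounds named here.

Working notes on the series in a functional assay on CHO cells for antagonist activity at Orexin receptor type 2 (Homo sapiens), read by FLIPR and calcium flux; on this read-out lower numbers stand for stronger inhibition and higher numbers for weaker inhibition.

Among the measured compounds shown here, compound 2 `CNC(=O)[C@@H](c1ccccc1)N1CCn2c(CC3CC3)nc(Cl)c2[C@@H]1CCc1ccc(C(F)(F)F)cc1` gives 35 nM, the lowest of the three numbers measured so far. Compound 3 `CCc1ncc2n1CCN([C@@H](C(=O)NC)c1ccccc1)C2CCc1ccc(C(F)(F)F)cc1` gives 194 nM, and compound 1 `CCc1nc(C(C)C)c2n1CCN([C@@H](C(=O)NC)c1ccccc1)C2CCc1ccc(C(F)(F)F)cc1` gives 2900 nM. For the measured compounds named here, the one step measured within one change is a 15-fold lower number from compound 1 to compound 3 (1.17 log units; beyond the scatter), which puts hydrogen in place of isopropyl on an aromatic carbon of the shared core.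

Compound 4 `CNC(=O)[C@@H](c1ccccc1)N1CCn2c(C)nc(Cl)c2[C@@H]1CCc1ccc(C(F)(F)F)cc1` differs from compound 2 by hydrogen in place of cyclopropyl on a saturated chain carbon bound to an aromatic carbon; cut one bond further out, the same difference reads cyclopropylmethyl to methyl. Going by the values given here, no measured step bears directly on this change: the step from compound 1 to compound 3 removed an alkyl group from an aromatic carbon, not from a saturated chain carbon, and compound 2 and compound 4 carry chlorine where compound 1 carried isopropyl. Among the compounds with values here, the only guidance is that trimming an alkyl group did not raise the number. The expectation for compound 4 is therefore a step of a 1.6-fold higher number from compound 2 to compound 4 (0.20 log units; within the scatter) that stays near or within the scatter, with no strong direction. Compound 4 is estimated at 55 nM, between 15 nM and 200 nM, in this assay.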

Compound 4, half-maximal inhibitory concentration: 13 nM
For compound 4 the middle estimate is 4.2-fold (0.63 log units) above the measured one, and the stated range ends above it.
By their numbers in this assay, from the lowest: compound 4; then compound 2; then compound 3; then compound 1.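

In this assay the change from cyclopropylmethyl to methyl on the saturated chain carbon bound to an aromatic carbon gives a 2.7-fold lower number from compound 2 to compound 4 (0.43 log units; beyond the scatter) and shows that the cyclopropyl is not needed for a low number in this chlorine-bearing pair. Read with a 15-fold lower number from compound 1 to compound 3 (1.17 log units; beyond the scatter) at a different place on the shared core, this is a second step in which a smaller group goes with a lower number; no step shown goes against this, though two steps are a narrow base. No measurement at hand gives a reason for the step.

Open, on these data alone, is whether the low number holds with a longer chain such as n-butyl, or with an aminomethyl group, at this place. Also open, as far as these compounds go, is whether the same change gives a similar step without the chlorine.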